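The compounds below may be only part of what the source reports. "The series", "measured", "known", "first", "only" and "open" are said of these compounds alone.

Measured so far in a functional assay on PANC-1 cells (Homo sapiens) for inhibition, read by MTT assay, with a stated time of 24 h, tested at 10 uM; on this read-out lower numbers stand for less inhibition and higher numbers for more inhibition at the one concentration tested (going by the name of the read-out):
compound 1 `CCOc1cc(=O)n(CCCO)c2c1CC(C/C=C(\C)CCC=C(C)C)C(C)(C)C2`: 0.8%
compound 2 `COc1ccccc1NC(=O)Oc1cc(=O)n(CCCO)c2c1CC(C/C=C(\C)CCC=C(C)C)C(C)(C)C2`: 0%

Compound 2 and compound 1 give numbers within the scatter of one another, so neither can be set apart on this assay; the change a number 0.8 percentage points lower from compound 1 to compound 2 (within the scatter) sits inside the noise, and both compounds give numbers near zero at the one concentration tested.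

Compound 3 `CC(C)=CCC/C(C)=C/CC1Cc2c(OC(=O)Nc3ccc(F)c(Cl)c3)cc(=O)n(CCCO)c2CC1(C)C` has not yet been run in this assay. It differs from compound 2 by 3-chloro-4-fluorophenyl in place of 2-methoxyphenyl on an amide-type nitrogen. Among the compounds with values here, the single measured step concerns a different place, the oxygen on the aromatic ring, and says nothing about the aryl group on the amide-type nitrogen. Within the data shown here, no measured step therefore bears on this change. With both measured compounds near zero, the expectation for compound 3 is no step beyond the scatter, with a number 3 percentage points higher from compound 2 to compound 3 (within the scatter) as the estimated change. Compound 3 is estimated at 3%, within 0% to 15%.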

Compound 3, a percentage reported as inhibition, at one concentration (the size of the read-out at that concentration, not a potency): 0%
Compound 3: the middle estimate sits 3 percentage points above what was measured; the measured number falls inside the stated range.
By their numbers in this assay, from the lowest: compounds 2, 3 and 1 (each within the scatter of the next).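

Within the data shown here, at the aryl group on the amide-type nitrogen, 3-chloro-4-fluorophenyl in place of 2-methoxyphenyl gives the first reading for this position in this assay: no change at the digits printed from compound 2 to compound 3 (within the scatter). Against ethyl on the oxygen, the second aryl carbamoyl gives a number 0.8 percentage points lower from compound 1 to compound 3 (within the scatter), so neither of the two aryl carbamoyls can be set apart from ethyl in this assay, and replacing a methoxy-bearing aryl group with a halogen-bearing one does not separate the compounds. No evidence at hand bears on why these numbers stay together.

The compounds shown leave open whether a non-aromatic group on the amide-type nitrogen, such as a dialkylaminoethyl chain, or a carboxylic acid on the phenyl ring would give a number beyond the scatter. They also leave open whether any change outside this carbamoyl position, such as a shorter chain in place of the long unsaturated one on the core, would do so.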